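Working notes: hydrogen in place of methoxy

The compounds below may be only part of what the source reports. "The series", "measured", "known", "first", "only" and "open" are said of these compounds alone.

Of the compounds shown here, two have numbers so far in a physicochemical assay for solubility, in phosphate buffer, measured as kinetic solubility, at pH 1, tested at 200 uM; a lower number here means a less soluble compound, a higher number a more soluble compound. Compound 1 `COc1ccc2c(=O)c(C)c(-c3cncc(-c4ccc(Cl)c(Cl)c4)c3)[nH]c2c1` gives 15000 nM, and compound 2 `COc1ccc2c(=O)c(C)c(-c3ccnc(-c4ccc(OC(F)(F)F)cc4)c3)[nH]c2c1` gives 120000 nM. Compound 2 therefore holds the higher of the two numbers, and the gap between them lies beyond the scatter.

The compound still without a number is compound 3 `Cc1c(-c2ccnc(-c3ccc(OC(F)(F)F)cc3)c2)[nH]c2ccccc2c1=O`. Its structure differs from that of compound 2 as follows: hydrogen in place of methoxy on an aromatic carbon. In words, this is hydrogen in place of methoxy on an aromatic carbon.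

Among the measured compounds shown here, no measured pair differs in one place only, so the data hold no direct precedent for this change. The expectation therefore starts from compound 2 at 120000 nM and remains a judgement. In this assay, a step no larger than the scatter is expected, with no firm direction. The estimated 1.1-fold higher number from compound 2 to compound 3 (0.03 log units; within the scatter) is accordingly small. For compound 3 the expected value is 130000 nM, with an estimated range from 60000 nM to 200000 nM.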

Compound 3, solubility: 79000 nM
The estimate for compound 3 lay 1.6-fold (0.22 log units) above the measured number; the range from low to high includes it.
By their numbers in this assay, from the lowest: compound 1; then compounds 3 and 2 (each within the scatter of the next).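

In this assay, among the compounds shown here, hydrogen in place of methoxy on an aromatic carbon gives a 1.5-fold lower number from compound 2 to compound 3 (0.18 log units; within the scatter), and this is the first step between compounds that differ in one place. On this pair, the methoxy group, with its 2 heavy atoms and 1 hydrogen-bond acceptor, can leave this carbon of the core, meta to a fused ring and para to a fused ring, without a step beyond the scatter, so compound 3 at 79000 nM stays level with compound 2 in this read-out. No measurement of another kind bears on this pair, and the size of the step stays unexplained.

This single pair does not show whether an amine or a carboxylic acid on the same aromatic carbon would also stay within the scatter of compound 2. It also leaves open whether hydrogen in place of methoxy would give a similar step on the core of compound 1, which differs from compound 2 in more than one place and so offers no direct comparison.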